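A few compounds are considered here, and "the series" means these few. Any claim that something is new, unique, unknown or untested is made for them only; others in the source may bear on it.

Compound 1 `CC1SC(c2cccc(C(=O)NCCCCc3ccccc3)c2)N(c2ccc(C3CC3)cc2)C1=O` gives 10000 nM
Compound 2 `O=C(NCCCCc1ccccc1)c1cccc(C2SCC(=O)N2c2ccccn2)c1` gives 20000 nM
Compound 3 `O=C(NCCCCc1ccccc1)c1cccc(C2SCC(=O)N2c2ccccc2F)c1` gives 20000 nM

In a physicochemical assay for solubility, read by turbidimetry, measured as kinetic solubility, at pH 6.8 (a higher number here means a more soluble compound, a lower number a less soluble compound), compound 3 stands level with compound 2, and all three numbers lie within the usual scatter of one another.

Compound 4 `O=C(NCCCCc1ccccc1)c1cccc(C2SCC(=O)N2c2ccc(C3CC3)cc2)c1` has not yet been measured. It keeps the core of compound 3 and changes only the group on the amide-type nitrogen in the ring, where 4-cyclopropylphenyl takes the place of 2-fluorophenyl (4-cyclopropylphenyl in place of 2-fluorophenyl on an amide-type nitrogen in a ring). The incoming group brings a three-membered non-aromatic ring of carbon only, and the fluorine leaves.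

One measured step changed the group on this same nitrogen (no change at the digits printed from compound 2 to compound 3 (within the scatter)). Compound 1 already carries 4-cyclopropylphenyl on a slightly different core, and compound 1 gives 10000 nM, within the scatter of compound 3.

No step beyond the scatter is therefore expected in this assay, though the number may lean slightly towards that of compound 1. The expected change is small (a 1.7-fold lower number from compound 3 to compound 4 (0.22 log units; within the scatter)). For compound 4 the estimated value is 12000 nM, with an expected range from 5000 nM to 25000 nM.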

Compound 4, solubility: 2000 nM
For compound 4 the middle estimate is 6.0-fold (0.78 log units) above the measured one; the measured number lies below the stated range.
By their numbers in this assay, from the lowest: compound 4; then compounds 1, 2 and 3 (each within the scatter of the next).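

In this assay the group on the amide-type nitrogen in the ring can clearly shift the number: 4-cyclopropylphenyl gives a 10-fold lower number from compound 3 to compound 4 (1.00 log units; beyond the scatter) and also a 10-fold lower number from compound 2 to compound 4 (1.00 log units; beyond the scatter) while the earlier swap on this nitrogen gave only no change at the digits printed from compound 2 to compound 3 (within the scatter). The methyl on the saturated ring carbon also counts when 4-cyclopropylphenyl is present, since hydrogen in its place gives a 5.0-fold lower number from compound 1 to compound 4 (0.70 log units; beyond the scatter) and the number for compound 1 therefore does not carry over to the core without that methyl. No measurement shown here explains either change.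

Plain phenyl or 4-methylphenyl on the same nitrogen would help show whether the shift follows the three-membered ring itself or any group at that end of the phenyl ring. On these data alone, it also remains open whether methyl on the ring carbon has the same effect alongside 2-fluorophenyl or pyridin-2-yl.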